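Pyrrolidinyl amide: inverting the ring stereocentre

This account rests on a few compounds, and the source may have more. Where it says the series, first, only, none or still open, it means among the compounds named here.

Measured in an assay on isolated protein for displacement of a labelled ligand from secreted frizzled-related protein 1 (Homo sapiens), read by fluorescence polarization, with a stated time of 30 min; on this read-out higher numbers stand for weaker inhibition and lower numbers for stronger inhibition:
compound 1, `O=C(c1ccccn1)N1CCC(NS(=O)(=O)c2cc(S(=O)(=O)c3ccccc3)ccc2C(F)(F)F)CC1`: 60 nM
compound 2, `CN(C)c1ccc(C(=O)N2CCC(NS(=O)(=O)c3cc(S(=O)(=O)c4ccccc4)ccc3C(F)(F)F)CC2)cn1`: 40 nM
compound 3, `O=C([C@H]1CCNC1)N1CCC(NS(=O)(=O)c2cc(S(=O)(=O)c3ccccc3)ccc2C(F)(F)F)CC1`: 40 nM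

All three numbers sit close together. Compound 3 stands level with compound 2 at the digits shown, and the step of a 1.5-fold lower number from compound 1 to compound 3 (0.18 log units; within the scatter) is within the scatter, as are a 1.5-fold lower number from compound 1 to compound 2 (0.18 log units; within the scatter) and no change at the digits printed from compound 2 to compound 3 (within the scatter). Changing the group on the carbonyl carbon has therefore left this assay essentially unmoved across the three compounds.

Compound 4, `O=C([C@@H]1CCNC1)N1CCC(NS(=O)(=O)c2cc(S(=O)(=O)c3ccccc3)ccc2C(F)(F)F)CC1`, is the unmeasured partner of compound 3. The change is the two compounds have the same atoms and bonds and differ only in configuration as drawn: 1 of 1 stereo elements differ; a stereocentre at a saturated ring carbon is drawn S in compound 3 and R in compound 4. For the measured compounds named here, none of the measured steps touches configuration; they all concern the group on the carbonyl carbon, and each was within the scatter. Going by the values given here, no step here shows how large a change at a stereocentre can be, so the measured steps give no direction. The expectation is a step of a 1.5-fold higher number from compound 3 to compound 4 (0.18 log units; within the scatter), with a wide range to allow for the absence of any stereochemical comparison. Compound 4 is estimated at 60 nM, between 25 nM and 160 nM in this assay.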

Compound 4, half-maximal inhibitory concentration in the secreted frizzled-related protein 1 assay: 60 nM
Compound 4: the middle estimate sits on the measured number at the digits printed; low and high end bracket the measured number.
By their numbers in the secreted frizzled-related protein 1 assay, from the lowest: compounds 2, 3, 1 and 4 (each within the scatter of the next).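

Inverting the ring stereocentre is the only change of configuration shown. In the secreted frizzled-related protein 1 assay compound 3 gives 40 nM and compound 4 gives 60 nM. In the secreted frizzled-related protein 1 assay the inversion stays within the scatter (a 1.5-fold higher number from compound 3 to compound 4 (0.18 log units; within the scatter)). In the secreted frizzled-related protein 1 assay compound 4 also stays within the scatter of the two pyridinyl amides (a 1.5-fold higher number from compound 2 to compound 4 (0.18 log units; within the scatter); no change at the digits printed from compound 1 to compound 4 (within the scatter)), so among these four compounds neither the group on the carbonyl carbon nor the configuration at this stereocentre produces a step beyond the scatter. In a physicochemical assay for solubility, at pH 7.4 (on this read-out lower numbers stand for lower solubility and higher numbers for higher solubility), compound 3 gives 77000 nM and compound 4 gives 70000 nM. The same holds in the physicochemical assay (a 1.1-fold lower number from compound 3 to compound 4 (0.04 log units; within the scatter)), and both readings concern configuration alone: the fact that compounds 3 and 4 differ only in the configuration as drawn.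

From the compounds shown here alone, whether a primary amine or a carboxylic acid in place of pyrrolidin-3-yl on the carbonyl carbon would give a step beyond the scatter in the secreted frizzled-related protein 1 assay remains open. Also open, going by these compounds, is whether configuration would matter with a methyl group on the pyrrolidine nitrogen.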